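Swapping the aryl urea end of compound 2

The compounds below may be only part of what the source reports. "The series", "measured", "known", "first", "only" and "open" are said of these compounds alone.

- compound 1 `COc1ccc(NC(=O)NCCNS(=O)(=O)c2sccc2-c2ccc(C)cc2Oc2ccc(O)c(O)c2)cc1`: 6100 nM
- compound 2 `COc1ccc(NC(=S)NCCNS(=O)(=O)c2sccc2-c2ccc(C)cc2Oc2ccc(O)c(O)c2)cc1`: 4100 nM

In a functional assay on HL-60 cells (Homo sapiens) for inhibition, read by CCK-8 assay, with a stated time of 48 h (a lower number here means a stronger inhibitor, a higher number a weaker inhibitor), compound 2 gives 4100 nM, which is level with compound 1 within the scatter. Compound 3 `Cc1ccc(-c2ccsc2S(=O)(=O)NCCNC(=O)Nc2ccc([N+](=O)[O-])cc2)c(Oc2ccc(O)c(O)c2)c1` brings in (4-nitrophenyl)carbamoyl on the same amine nitrogen: a group of 12 heavy atoms (7 carbon, 2 nitrogen, 3 oxygen; one six-membered aromatic ring of carbon only) in place of a group of 11 heavy atoms (8 carbon, 1 nitrogen, 1 oxygen, 1 sulfur; one six-membered aromatic ring of carbon only), on an amine nitrogen. Going by the values given here, the only measured step at this nitrogen, a 1.5-fold lower number from compound 1 to compound 2 (0.17 log units; within the scatter), was small. Among the compounds with values here, no measured compound carries the new group, so this is thin evidence. In this assay the expected change is a 1.2-fold higher number from compound 2 to compound 3 (0.09 log units; within the scatter), which means no step beyond the scatter. For compound 3 the estimated value is 5000 nM, with an expected range of 2000 nM to 12000 nM.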

Compound 3, half-maximal inhibitory concentration: 3900 nM
The estimate for compound 3 lay 1.3-fold (0.11 log units) above the measured number; measured number inside the range.
By their numbers in this assay, from the lowest: compounds 3, 2 and 1 (each within the scatter of the next).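

At this amine nitrogen, (4-nitrophenyl)carbamoyl reads level with the earlier groups in this assay: the swap gives a 1.1-fold lower number from compound 2 to compound 3 (0.02 log units; within the scatter) and nitro in place of methoxy on an aromatic carbon gives a 1.6-fold lower number from compound 1 to compound 3 (0.19 log units; within the scatter) in the same assay. Across these three compounds, then, changing this end of the molecule produces no step beyond the scatter. No measurement shown explains this flat reading. Still open, on these data alone, is whether a carboxylic acid or an amine on that aromatic ring, or a longer chain to the amine nitrogen, would shift the number beyond the scatter.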